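From sec-butyl to tert-butyl: same atoms, rearranged

The compounds below may be only part of what the source reports. "The series", "measured", "known", "first", "only" and "open" are said of these compounds alone.

Among the measured compounds shown here, only two compounds have been measured so far in a functional assay on RAW264.7 cells (Mus musculus) for inhibition, read by ELISA, with a stated time of 24 h; a lower number here means that less compound is needed, a higher number that more compound is needed for the effect. Compound 1 `CC/C=C\C[C@H]1C(=O)C=C[C@H]1CC(=O)OCc1ccccc1` gives 20000 nM, and compound 2 `CC/C=C\C[C@H]1C(=O)C=C[C@H]1CC(=O)OC(C)CC` gives 22000 nM. These two values lie within the usual scatter of each other, so compound 2 cannot be told apart from compound 1 on these numbers.

The next compound is compound 3 `CC/C=C\C[C@H]1C(=O)C=C[C@H]1CC(=O)OC(C)(C)C`, which has the same atoms as compound 2, joined differently: tert-butyl in place of sec-butyl on an oxygen next to a carbonyl group. In words, it has tert-butyl in place of sec-butyl on an oxygen next to a carbonyl group.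

For the measured compounds named here, one measured step bears on this change. It touches the same place: sec-butyl in place of benzyl, which gave a 1.1-fold higher number from compound 1 to compound 2 (0.04 log units; within the scatter). That step stayed within the scatter. Going by the values given here, it is thin evidence, since it is a single step and no measured compound carries tert-butyl. Even so, a change at this place has so far left the number where it was, so no shift beyond the scatter is expected in this assay. The expected step is no change at the digits printed from compound 2 to compound 3 (within the scatter). Compound 3 is estimated at 22000 nM, with an expected range of 10000 nM to 50000 nM.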

Compound 3, half-maximal effective concentration: 20000 nM
Estimate against measurement, compound 3: 1.1-fold (0.04 log units) above; low and high end bracket the measured number.
By their numbers in this assay, from the lowest: compounds 1, 3 and 2 (each within the scatter of the next).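

In this assay, tert-butyl in place of sec-butyl gives a 1.1-fold lower number from compound 2 to compound 3 (0.04 log units; within the scatter), and tert-butyl in place of benzyl gives no change at the digits printed from compound 1 to compound 3 (within the scatter). The group on an oxygen next to a carbonyl group has now been benzyl, sec-butyl and tert-butyl, and all three compounds lie within the scatter of one another. Neither rearranging the same atoms nor replacing the ring of benzyl with a branched chain gives a number that can be told apart, but nothing shown explains why this place behaves so evenly.

From the compounds shown here alone, what stays open is whether the number would hold with a different kind of group at this place, such as an amine-bearing chain, a longer chain, or a carboxylic acid with no group on that oxygen. All three compounds also share the same core, so they do not show how a change elsewhere on that core would move the number in this assay or whether any such change would separate compounds beyond the scatter.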